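A Second Methyl on the Pyridyl Ether of Compound 3

The source may report more compounds than this note shows. Statements on the series, on what has been measured and on what is new or still open speak of the compounds shown alone.

Measured in a functional assay on CHO cells for positive allosteric modulation of metabotropic glutamate receptor 2 (Homo sapiens), read by scintillation counting and GTPgammaS binding, with a stated time of 30 min; on this read-out higher numbers stand for an effect only at larger amounts of compound and lower numbers for an effect already at smaller amounts:
compound 1 `CC(C)CCn1ccc(-c2ccc(OCC3CC3)c(Cl)c2)c(C#N)c1=O` — 110 nM
compound 2 `Cc1ncccc1Oc1ccc(-c2ccn(CCC(C)C)c(=O)c2C#N)cc1` — 275 nM
compound 3 `Cc1ncccc1Oc1ccc(-c2ccn(CC3CC3)c(=O)c2C#N)cc1` — 1070 nM

Compound 3 carries the highest number of the three. Its nearest neighbour is compound 2, as shown by a 3.9-fold higher number from compound 2 to compound 3 (0.59 log units; beyond the scatter), a change of cyclopropyl in place of isobutyl on a saturated chain carbon bound to an aromatic nitrogen. Compound 1, with 110 nM, stands lower still, though it differs from compound 3 in more than one place.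

Compound 4 `Cc1ccc(Oc2ccc(-c3ccn(CC4CC4)c(=O)c3C#N)cc2)c(C)n1` is obtained from compound 3 by methyl in place of hydrogen on an aromatic carbon. Among the measured compounds shown here, no measured step touches this part of the molecule: the one step seen, a 3.9-fold higher number from compound 2 to compound 3 (0.59 log units; beyond the scatter), concerns the chain on the ring nitrogen of the shared core and says nothing about the pyridyl ether. With nothing to guide the direction, a step of a 1.1-fold lower number from compound 3 to compound 4 (0.05 log units; within the scatter) is expected, that is, none beyond the scatter. Compound 4 is therefore estimated at 950 nM in this assay, within a range of 300 nM to 3000 nM.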

Compound 4, half-maximal effective concentration: 263 nM
For compound 4 the middle estimate is 3.6-fold (0.56 log units) above the measured one; the whole stated range lies above it.
By their numbers in this assay, from the lowest: compound 1; then compounds 4 and 2 (each within the scatter of the next); then compound 3.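

Among the compounds shown here, the methyl that enters on the aromatic carbon next to the ring nitrogen, para to a large group, is the first change here to touch the pyridyl ether, and in this assay it gives a 4.1-fold lower number from compound 3 to compound 4 (0.61 log units; beyond the scatter). This position is therefore not indifferent: set beside a 3.9-fold higher number from compound 2 to compound 3 (0.59 log units; beyond the scatter), a change in the chain on the ring nitrogen of the shared core, the step shows that the pyridyl ether can also move the number beyond the scatter, and in the opposite direction. No evidence at hand bears on the reason for this step. Going by these compounds, how an ethyl, a methoxy or a chlorine on this same carbon would compare stays open. Also open, on these data alone, is whether the added methyl would give a step of like size with the isobutyl chain in place of cyclopropyl.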